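The source may report more compounds than this note shows. Statements on the series, on what has been measured and on what is new or still open speak of the compounds shown alone.

Compounds measured so far in a functional assay on SW1573 cells (Homo sapiens) for antiproliferative activity, read by sulforhodamine B assay, with a stated time of 48 h (a higher number here means a weaker inhibitor of growth, a lower number a stronger inhibitor of growth), are:

Compound 1 (`CC(C)(C)[Si](C)(C)O[C@H]1CCCO[C@@H]1CO`) gives > 100000 nM as a limit
Compound 2 (`CC(C)(C)[Si](C)(C)O[C@@H]1CCCO[C@@H]1CO`) gives > 100000 nM as a limit

Compound 2 stands at > 100000 nM in this assay, which is a limit and not a number. Among the compounds with values here, neither compound has yet given a number, and the only reading is the limit of > 100000 nM in this assay, at which 2 of the 2 values shown sit, for the pair. Within the data shown here, the one measured step is a step that the two limits leave unreadable from compound 1 to compound 2, and it concerns the fact that compounds 1 and 2 differ only in the configuration as drawn alone. It offers no size to carry forward.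

Compound 3 (`CC(C)(C)[Si](C)(C)O[C@@H]1CCCO[C@@H]1COCC(=O)O`) differs from compound 2 by carboxymethyl in place of hydrogen on an oxygen on a saturated carbon as its change: carboxymethyl in place of hydrogen on an oxygen on a saturated carbon, turning hydroxymethyl to (carboxymethoxy)methyl. Among the measured compounds shown here, no measured step touches this change, so no direction can be read for it in this assay, and compound 3 is expected to stay close to the limit, quite possibly reported as a limit itself. That expectation rests on compound 2 with its limit of > 100000 nM and nothing more. The expected size is a number no higher from compound 2 to compound 3 (the limit leaves the size open) and should be taken as nominal. For compound 3 the estimate is 100000 nM with an expected range from 40000 nM to 200000 nM in this reading.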

Compound 3, concentration for 50% growth inhibition: > 100000 nM
Compound 3 ended at the assay's limit; the forecaster's own chance of this, stated with the estimate: 70%; the middle value lies on the limit itself.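

In this assay compound 3 gives > 100000 nM, which is a limit and not a number. Compound 2 also sits at a limit, and no step can be read between compound 2 and compound 3. The compounds shown leave open whether any change to the shared core would give a number in this assay, and what size the carboxymethyl change or the configuration as drawn would then have.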